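A few compounds are considered here, and "the series" means these few. Any claim that something is new, unique, unknown or untested is made for them only; others in the source may bear on it.

Measured compounds:
- compound 1, `O=C(Nc1ncc(C(=O)O)c2nc(-c3ccco3)nn12)NC1CCCCC1`: > 100000 nM
- compound 2, `CCOC(=O)c1cnc(NC2CC2)n2nc(-c3ccco3)nc12`: 60.7 nM

Compound 1 `O=C(Nc1ncc(C(=O)O)c2nc(-c3ccco3)nn12)NC1CCCCC1` carries a carboxylic acid on the shared core and a cyclohexylcarbamoyl group on the ring nitrogen. In an assay on CHO cells for displacement of a labelled ligand from adenosine receptor A1 (Homo sapiens) (a lower number here means a stronger inhibitor, a higher number a weaker inhibitor), compound 1 reaches only the limit of the assay, > 100000 nM, and no number is known for it; this is the point at which (the limit of > 100000 nM in this assay, at which 1 of the 2 values shown sits). For the measured compounds named here, compound 2 `CCOC(=O)c1cnc(NC2CC2)n2nc(-c3ccco3)nc12`, an ethyl ester with a cyclopropylamino group, gives 60.7 nM in this assay; it differs from compound 1 in two places, so the two values show only that compound 2 is measurable and compound 1 is not.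

Compound 3 `COc1ccc(CNc2ncc(C(=O)O)c3nc(-c4ccco4)nn23)cc1` keeps the carboxylic acid of compound 1 and changes only the ring nitrogen substituent: 4-methoxybenzyl in place of cyclohexylcarbamoyl on a nitrogen on an aromatic ring. Going by the values given here, no measured pair mirrors this change, and the acid that compound 1 shares with compound 3 is the one constant feature of the only compound that sits at the limit. Compound 3 is therefore expected to stay weak, with the step of an at least 2.0-fold lower number from compound 1 to compound 3 (0.30 log units; that floor lies within the scatter) at best small and the result more likely a limit than a number. The estimate for compound 3 in this assay is 50000 nM, within 5000 nM to 200000 nM.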

Compound 3, inhibition constant: 5760 nM
The estimate for compound 3 lay 8.7-fold (0.94 log units) above the measured number; the measured number falls inside the stated range.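

Compound 3 keeps the carboxylic acid of compound 1, and in this assay compound 3 gives 5760 nM as a measured number, so the acid on the shared core does not by itself keep a compound from giving a measured number. For the compounds shown here, with the acid held constant, 4-methoxybenzyl in place of cyclohexylcarbamoyl on a nitrogen on an aromatic ring gives an at least 17-fold lower number from compound 1 to compound 3 (1.23 log units; beyond the scatter) and is the first change that can be read in one place. For compound 1 the value > 100000 nM is a limit of the assay and not a number, so this step is only a floor: the limit of > 100000 nM in this assay, at which 1 of the 3 values shown sits.

Compound 2 carries an ethyl ester and a cyclopropylamino group and differs from compound 3 in two places, so the share of each place cannot be read from those two values. Still open, going by these compounds, are what a plain benzyl group or a longer alkyl chain would give on that nitrogen, and what the ethyl ester would give with 4-methoxybenzyl kept in place.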